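A few compounds are considered here, and "the series" means these few. Any claim that something is new, unique, unknown or untested is made for them only; others in the source may bear on it.

Measured so far in an ADME assay on Vero cells (Chlorocebus sabaeus) for cytotoxicity, read by MTT assay; on this read-out lower numbers stand for higher toxicity in this test and higher numbers for lower toxicity in this test:
compound 1 `Cn1nc(C(F)(F)F)cc1C(=O)Nc1ccc(S(=O)(=O)N2CCCCC2)cc1` — > 300000 nM (a limit)
compound 2 `Cn1nc(C(F)(F)F)cc1C(=O)Nc1ccc(S(=O)(=O)N2CCOCC2)cc1` — > 300000 nM (a limit)
compound 3 `Cn1nc(C(F)(F)F)cc1C(=O)Nc1ccc(S(=O)(=O)N2CCNCC2)cc1` — 126000 nM

Compound 1 sits at a limit of this assay, (the limit of > 300000 nM in this assay, at which 2 of the 3 values shown sit), so its number is not known. Compound 3 gives a number, and the step of an at least 2.3-fold lower number from compound 1 to compound 3 (0.37 log units; beyond the scatter) is at least modest; the same holds for an at least 2.3-fold lower number from compound 2 to compound 3 (0.37 log units; beyond the scatter). The step that the two limits leave unreadable from compound 1 to compound 2 cannot be read.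

Compound 4 `Cn1nc(C(F)(F)F)cc1C(=O)Nc1ccc(S(=O)(=O)N2CCC(N)CC2)cc1` differs from compound 1 by amino in place of hydrogen on a saturated ring carbon. The nearest measured step is an at least 2.3-fold lower number from compound 1 to compound 3 (0.37 log units; beyond the scatter), which also brings a nitrogen into the six-membered ring region and lowers the number. A step of similar size is therefore expected, an at least 2.0-fold lower number from compound 1 to compound 4 (0.30 log units; that floor lies within the scatter), though a limit is again possible. Compound 4 is estimated at 150000 nM, range 60000 nM to 300000 nM.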

Compound 4, half-maximal cytotoxic concentration: > 300000 nM
Compound 4 was reported as a limit (the forecaster's own chance of this, stated with the estimate: 40%); middle value at least 2.0-fold (0.30 log units) away from the limit.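

In this assay, amino on a saturated ring carbon, three ring bonds from the ring nitrogen, does not reproduce the lower number of compound 3, and the change to 4-aminopiperidin-1-yl gives an at least 2.3-fold higher number from compound 3 to compound 4 (0.37 log units; beyond the scatter). Compound 4 gives > 300000 nM, which is a limit. The steps among compound 1, compound 2 and compound 4 cannot be read: the limit of > 300000 nM in this assay, at which 3 of the 4 values shown sit.

On these data alone, how far these three compounds lie apart remains open. Also open, as far as these compounds go, is whether a carboxylic acid or a longer amine chain on that ring carbon would leave the number at the limit.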